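The source may report more compounds than this note shows. Statements on the series, on what has been measured and on what is new or still open speak of the compounds shown alone.

Measured compounds:
- compound 1 `C[C@@H](O)[C@H]1C(=O)N2C(C(=O)OCOC(=O)C(C)(C)C)=C(S[C@@H]3CN[C@H](C(=O)Nc4cccc(C(=O)O)c4)C3)[C@H](C)[C@H]12` — in a physicochemical assay for metabolic stability, read by LC-MS, in phosphate buffer, with a stated time of 3 h, at pH 7.4, tested at 50 uM (on this read-out higher numbers stand for a more stable compound and lower numbers for a less stable compound), compound 1 gives > 95%, which is a limit of the assay rather than a number.
- compound 2 `CCC(CC)C(=O)OCOC(=O)C1=C(S[C@@H]2CN[C@H](C(=O)Nc3cccc(C(=O)O)c3)C2)[C@H](C)[C@@H]2[C@@H]([C@@H](C)O)C(=O)N12` — in this assay compound 2 gives > 95%, again a limit.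
- compound 3 `CC(C)OC(=O)C1=C(S[C@@H]2CN[C@H](C(=O)Nc3cccc(C(=O)OC(C)C)c3)C2)[C@H](C)[C@@H]2[C@@H]([C@@H](C)O)C(=O)N12` — in this assay compound 3 gives > 95%, also a limit.

Compound 3 therefore stands at the same limit as the two other measured compounds (the limit of > 95% in this assay, at which 3 of the 3 values shown sit). Among the compounds with values here, the one step among measured compounds, a step that the two limits leave unreadable from compound 1 to compound 2, cannot be read as a size, so it gives no measure of how far a change to the ester part moves this read-out.

Compound 4 `CC(C)OC(=O)C1=C(S[C@@H]2CN[C@H](C(=O)Nc3cccc(C(=O)O)c3)C2)[C@H](C)[C@@H]2[C@@H]([C@@H](C)O)C(=O)N12` differs from compound 3 in one place: hydrogen in place of isopropyl on an oxygen next to a carbonyl group. The group that leaves is a small hydrocarbon chain, and what remains is a carboxylic acid. Within the data shown here, no measured step covers this kind of change, so no size can be taken from the data for it. What the data do show is that every measured compound, with or without an acid at that position, sits at the limit (the limit of > 95% in this assay, at which 3 of the 3 values shown sit).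

Compound 4 is therefore expected to stay at or near the limit, and the step that the limit leaves unreadable from compound 3 to compound 4 is estimated to be none beyond the scatter. Compound 4 is estimated at 96%, between 85% and 100%.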

Compound 4, percent of the compound remaining: > 95%
Compound 4 gave a limit, no number; the forecaster's own chance of this, stated with the estimate: 80%; the middle value does not contradict the limit.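

Compound 4 sits at the same limit as compound 1, compound 2 and compound 3, so none of the steps joining it to them can be read as a size: the limit of > 95% in this assay, at which 4 of the 4 values shown sit. The compounds shown leave open how far apart they truly lie, and whether any change to the ester part would bring a compound down to a readable number.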